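A few compounds are considered here, and "the series" means these few. Any claim that something is new, unique, unknown or untested is made for them only; others in the source may bear on it.

Values in an ADME assay on cells (Hepatocyte, Homo sapiens) for metabolic stability, read by LC-MS, with a stated time of 180 min, tested at 1 uM (on this read-out lower numbers stand for slow clearance and higher numbers for fast clearance), for the measured compounds
Compound 1 `CC(C(=O)O)c1nn(Cc2cn3cc(OCC4CC4)c(Cl)cc3n2)c2ccccc2c1=O` gives < 8.34 mL/min/kg
Compound 2 `CC(C)(C(=O)O)c1nn(Cc2cn3cc(OCC4CC4)c(Cl)cc3n2)c2ccccc2c1=O` gives < 10 mL/min/kg
Compound 3 `CCC(C(=O)O)c1nn(Cc2cn3cc(OCC4CC4)c(Cl)cc3n2)c2ccccc2c1=O` gives < 8.34 mL/min/kg

Each of these three values is a limit of the assay and not a number. Compound 2 stands at the limit of < 10 mL/min/kg in this assay, at which 1 of the 3 values shown sits, and has no number of its own. Compound 3 stands at the limit of < 8.34 mL/min/kg in this assay, at which 2 of the 3 values shown sit, and likewise has no number of its own.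

The change to compound 4 `C[C@H](C(=O)O)c1nn(Cc2cn3cc(OCC4CC4)c(Cl)cc3n2)c2ccccc2c1=O` is 1-carboxyethyl in place of 1-carboxypropyl on an aromatic carbon and amounts to 1-carboxyethyl in place of 1-carboxypropyl on an aromatic carbon, with 1 defined stereocentre in the entering group.

Within the data shown here, three measured steps bear on this change. The nearest is a step that the two limits leave unreadable from compound 1 to compound 3 and it adds a methyl on the saturated chain, the opposite way round from the change at hand. The other two are a step that the two limits leave unreadable from compound 1 to compound 2 and a step that the two limits leave unreadable from compound 2 to compound 3 and neither gives a size. With no readable size in any of them, no step beyond the usual scatter is expected in this assay and no direction can be stated.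

The expected step is a step that the limit leaves unreadable from compound 3 to compound 4 and it remains an estimate resting on limits alone. The estimated clearance for compound 4 is 6.5 mL/min/kg within an expected range from 3.5 mL/min/kg to 10 mL/min/kg and a report as a limit alone is likely.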

Compound 4, clearance: 6.67 mL/min/kg
Estimate against measurement, compound 4: 1.0-fold (0.01 log units) below, and the stated range covers the measured number.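

In this assay compound 4 now carries a number, while compound 1, compound 2 and compound 3 stand only as limits, and none of the steps to compound 4 can be read. The compounds shown leave open how clearance compares across the 1-carboxyethyl, 1-carboxypropyl and 1-carboxy-1-methylethyl groups, and whether the defined configuration of compound 4 matters at all.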